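Methoxy to cyano on the aryloxy ring: a second look

A few compounds are considered here, and "the series" means these few. Any claim that something is new, unique, unknown or untested is made for them only; others in the source may bear on it.

Measured compounds in a functional assay on the whole organism with Rattus norvegicus as the target; on this read-out lower numbers stand for an effect already at smaller amounts and higher numbers for an effect only at larger amounts of compound:
compound 1, `COc1ccccc1OCC(O)CNCC(=O)Nc1ccc(C2=NNC(=O)CC2C)cc1`, 3 umol/kg;
compound 2, `CC1CC(=O)NN=C1c1ccc(NC(=O)CNCC(O)COc2ccccc2C#N)cc1`, 0.9 umol/kg;
compound 3, `COc1ccccc1OCC(O)CNCCC(=O)Nc1ccc(C2=NNC(=O)CC2)cc1`, 4.3 umol/kg.

Compound 1 and compound 2 differ in one place only, (cyano in place of methoxy on an aromatic carbon), and the step of a 3.3-fold lower number from compound 1 to compound 2 (0.52 log units; beyond the scatter) is beyond the usual scatter of this assay. Compound 3 carries the same methoxy-bearing aryloxy piece as compound 1 but on a different core; the two have the same atoms joined differently, and the difference between the two cores is not broken down here. In this assay compound 3 gives a number that stands within the scatter of compound 1, so no order between them is claimed.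

Compound 4, `N#Cc1ccccc1OCC(O)CNCCC(=O)Nc1ccc(C2=NNC(=O)CC2)cc1`, is not yet measured. It differs from compound 3 by cyano in place of methoxy on an aromatic carbon, which is the same change as that from compound 1 to compound 2, at the same place on the ring. Going by the values given here, the expectation rests on compound 3 with its value of 4.3 umol/kg as the starting point and on the single measured instance of this change, a 3.3-fold lower number from compound 1 to compound 2 (0.52 log units; beyond the scatter). A step of about the same size is expected, a 3.3-fold lower number from compound 3 to compound 4 (0.52 log units; beyond the scatter). From the compounds shown here alone, whether the change carries over from one core to the other is untested, so the range is kept wide. For compound 4 in this assay the estimated value is 1.3 umol/kg, between 0.6 umol/kg and 3.5 umol/kg.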

Compound 4, dose for half-maximal effect: 1.7 umol/kg
The estimate for compound 4 lay 1.3-fold (0.12 log units) below the measured number; the range from low to high includes it.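

Cyano in place of methoxy on an aromatic carbon again goes with a lower number in this assay on the second core, a 2.5-fold lower number from compound 3 to compound 4 (0.40 log units; beyond the scatter), so the direction seen on the core of compound 1 also holds on the core of compound 3. This does not show that the change will carry over to any further core: the claim rests on two pairs only, both read in a single whole-organism assay, and such numbers say nothing about how the change produces its effect. Within those limits the two steps cannot be told apart in size, so one step size serves for both cores, and no dependence on the core can be read from them: the same change on two cores in this assay, a 3.3-fold lower number (0.52 log units; beyond the scatter) from compound 1 to compound 2 and a 2.5-fold lower number (0.40 log units; beyond the scatter) from compound 3 to compound 4, 1.3-fold (0.12 log units) apart, within the scatter of two such steps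

The compounds shown leave open whether other groups at this place on the ring, such as a chlorine atom, a trifluoromethyl or an amine, would give a step of similar direction and size to that of the cyano group. Also open, from the compounds shown here alone, are what separates the two cores themselves, which these pairs do not break down, and whether the cyano step would persist on a core with a longer chain or with a carboxylic acid added.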